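The source may report more compounds than this note shows. Statements on the series, on what has been measured and on what is new or still open speak of the compounds shown alone.

Three compounds measured in an assay on HEK293 cells for inhibition of transient receptor potential cation channel subfamily V member 1 (Homo sapiens), read by FLIPR (a lower number here means a stronger inhibitor, a higher number a weaker inhibitor), share a urea that joins a piperazine to an aromatic ring. Compound 1 `O=C(Nc1nc2ccc(F)cc2s1)N1CCN(c2ccc(Cl)nn2)CC1` gives > 10000 nM in this assay, a limit of the assay rather than a number. Compound 3 `O=C(Nc1nc2ccc(F)cc2s1)N1CCN(c2cccnn2)CC1` likewise gives > 10000 nM in this assay, again a limit. Compound 2 `Cc1cc(N2CCN(C(=O)Nc3ccc(C(C)C)cc3)CC2)nnc1Cl` gives > 10000 nM in this assay, which is also a limit. The change from compound 1 to compound 3 is hydrogen in place of chloro on an aromatic carbon, and its step that the two limits leave unreadable from compound 1 to compound 3 cannot be read because both of its ends sit at the limit of > 10000 nM in this assay, at which 3 of the 3 values shown sit. The difference between the core of compound 1 and the core of compound 2 is not broken down here.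

Compound 4 `Cc1cnnc(N2CCN(C(=O)Nc3ccc(C(C)C)cc3)CC2)c1` is not yet measured. It differs from compound 2 by hydrogen in place of chloro on an aromatic carbon, the same kind of change as from compound 1 to compound 3, though here the place is ortho to a methyl group. Since compound 2 shows only the limit > 10000 nM and compound 1 to compound 3 gave an unreadable step, the expected step that the limit leaves unreadable from compound 2 to compound 4 is small. Compound 4 is estimated at 20000 nM, between 8000 nM and 60000 nM, most likely again only a limit.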

Compound 4, half-maximal inhibitory concentration: 5020 nM
Compound 4: the middle estimate sits 4.0-fold (0.60 log units) above what was measured; measured number below the stated range.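

In this assay, hydrogen in place of chloro gives an at least 1.9-fold lower number from compound 2 to compound 4 (0.29 log units; that floor lies within the scatter), and compound 4, at 5020 nM, has the only true number among the compounds shown. From the compounds shown here alone, this shows that the chloro-free compound on this core can be measured, but the floor of the step alone does not establish a real gain, and the full size of the step stays unknown. Whether the change carries over from one core to another also stays unanswered, because the step from compound 1 to compound 3 cannot be read, with both of its ends at a limit: the limit of > 10000 nM in this assay, at which 3 of the 4 values shown sit.

The compounds shown leave open what a methoxy group or an amine in place of the chloro would do on either core. An ethyl group in place of the methyl of compound 4 is likewise an open case, and it could show how much that neighbouring group matters to the result.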